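This account rests on a few compounds, and the source may have more. Where it says the series, first, only, none or still open, it means among the compounds named here.

Series notes. Compound 3 `CCO[C@H]1C[C@@H](c2coc3ccccc3c2=O)N(c2ccccc2)O1` carries only hydrogen on the fused ring. In a functional assay on A549 cells (Homo sapiens) for inhibition, read by sulforhodamine B assay, with a stated time of 48 h (a lower number here means a stronger inhibitor, a higher number a weaker inhibitor), compound 3 gives > 60000 nM; this is a limit of the assay, not a number. Among the three values shown, compound 3 is the one that reaches the assay limit. Compound 1 `CCO[C@H]1C[C@@H](c2coc3ccc(Br)cc3c2=O)N(c2ccccc2)O1` bears a bromo on the fused ring, and in this assay compound 1 gives 21500 nM. Among the measured compounds shown here, the step of an at least 2.7-fold higher number from compound 1 to compound 3 (0.44 log units; beyond the scatter) is the only measured step that touches the fused ring; its size is set by the limit of > 60000 nM in this assay, at which 1 of the 3 values shown sits. For the measured compounds named here, compound 2 `Cc1ccc2occ([C@@H]3C[C@H](c4ccccc4)ON3c3ccccc3)c(=O)c2c1` carries a methyl on the fused ring but differs from compound 3 in a second place too, so no single step connects them; in this assay compound 2 gives 49000 nM. Compound 4 `CCO[C@H]1C[C@@H](c2coc3ccc(C)cc3c2=O)N(c2ccccc2)O1` is compound 3 with methyl in place of hydrogen on an aromatic carbon. Because an at least 2.7-fold higher number from compound 1 to compound 3 (0.44 log units; beyond the scatter) shows a substituent at this position lowering the number, and compound 2 with a methyl there sits at 49000 nM, a modest lowering is expected for compound 4, an at least 1.5-fold lower number from compound 3 to compound 4 (0.17 log units; that floor lies within the scatter). Compound 4 is estimated at 40000 nM, range 15000 nM to 100000 nM.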

Compound 4, half-maximal inhibitory concentration: 20700 nM
The estimate for compound 4 lay 1.9-fold (0.29 log units) above the measured number, and the stated range covers the measured number.
By their numbers in this assay, from the lowest: compounds 4 and 1 (each within the scatter of the next); then compound 2. At a limit, above all of these: compound 3.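

Methyl on the fused ring now lowers the number just as bromo did, so the effect at this position does not belong to bromo alone; an at least 2.8-fold lower number from compound 3 to compound 4 (0.46 log units; beyond the scatter) is a bound on the step, not its size: the limit of > 60000 nM in this assay, at which 1 of the 4 values shown sits.
The exchange of bromo for methyl gives a 1.0-fold lower number from compound 1 to compound 4 (0.02 log units; within the scatter), so the two substituents cannot be told apart in this assay.
Among the compounds shown here, with the methyl held in place, ethoxy in place of phenyl on a saturated ring carbon gives a 2.4-fold lower number from compound 2 to compound 4 (0.37 log units; beyond the scatter), which shows for the first time in a single step that this second place also moves the number.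

From the compounds shown here alone, how an amine or a methoxy group would read on the same aromatic carbon stays open, as does the effect of a longer chain in place of ethoxy. Going by these compounds, the true number for compound 3 is also unknown, so the full size of both steps from hydrogen remains open.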